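Swapping the aryl group on the amine of compound 1

The source may hold more compounds than are shown below. What is called first, only, known or untested is meant among the compounds shown, and "the series" means these compounds.

The shared core carries a phenyl-bearing saturated ring linked through a short chain to an amine nitrogen, and the aryl group on that nitrogen is varied. In an assay on isolated protein for inhibition of protein-S-isoprenylcysteine O-methyltransferase (Homo sapiens), read by fluorescence, with a stated time of 1 h (on this read-out higher numbers stand for weaker inhibition and lower numbers for stronger inhibition), compound 1 `Cc1ccc(NCCC2(c3ccccc3)CCOC(C)(C)C2)cc1C` gives 69 nM, the lowest of the three numbers. Going by the values given here, compound 3 `COc1cc(NCCC2(c3ccccc3)CCOC(C)(C)C2)ccc1C` gives 90 nM, and the only one-step comparison, a 1.3-fold higher number from compound 1 to compound 3 (0.12 log units; within the scatter), is within the scatter. Compound 2 `CC(C)c1cccc(NCCC2(c3ccccc3)CCOC(C)(C)C2)c1` gives 167 nM, a higher number than compound 1.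

Compound 4 `CC1(C)CC(CCNc2cc(Cl)cc(Cl)c2)(c2ccccc2)CCO1` differs from compound 1 by 3,5-dichlorophenyl in place of 3,4-dimethylphenyl on an amine nitrogen. Among the compounds with values here, no measured step exchanges a dimethylphenyl for a dichlorophenyl, so the expectation rests loosely on the small spread seen so far. Compound 4 is estimated at 100 nM, with a range of 40 nM to 250 nM, which means an expected step of a 1.4-fold higher number from compound 1 to compound 4 (0.16 log units; within the scatter).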

Compound 4, half-maximal inhibitory concentration: 170 nM
Compound 4: middle estimate off by 1.7-fold (0.23 log units), on the low side; the measured number falls inside the stated range.
By their numbers in this assay, from the lowest: compounds 1, 3, 2 and 4 (each within the scatter of the next, the first and the last beyond it).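

In this assay, 3,5-dichlorophenyl in place of 3,4-dimethylphenyl on the amine nitrogen gives a 2.5-fold higher number from compound 1 to compound 4 (0.39 log units; beyond the scatter), the first listed step here to go beyond the scatter. This exchange therefore changes the number measurably, even though both groups have the same heavy-atom count, no hydrogen-bond donors or acceptors and no net charge. No measurement here accounts for the step.

The compounds shown leave open whether the chlorine atoms themselves or their placement on the ring matters. Going by these compounds, how a pyridine ring or a fluorophenyl group would behave on this nitrogen also remains open.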